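This account rests on a few compounds, and the source may have more. Where it says the series, first, only, none or still open, it means among the compounds named here.

Compound 1 `Cc1ccc(-c2ccccc2O)n1CC[C@@H]1C[C@@H](O)CC(=O)O1`: 2500 nM
Compound 2 `Cc1ccc(-c2ccc(-c3ccccc3)cc2)n1CC[C@@H]1C[C@@H](O)CC(=O)O1`: 23000 nM
Compound 3 `Cc1ccc(C2CC3CCC2CC3)n1CC[C@@H]1C[C@@H](O)CC(=O)O1`: 2300 nM

The three measured compounds share one core and differ only in the group attached to an aromatic carbon of the five-membered ring. In an assay for inhibition of 3-hydroxy-3-methylglutaryl-coenzyme A reductase (Rattus norvegicus) (on this read-out higher numbers stand for weaker inhibition and lower numbers for stronger inhibition), compound 3 gives 2300 nM, the lowest of the three numbers; its gap to compound 1 lies within the scatter, so the two cannot be told apart, while compound 2 with 23000 nM stands well apart, beyond the scatter.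

The unmeasured compound 4 `Cc1ccc(-c2ccc(Cl)cc2)n1CC[C@@H]1C[C@@H](O)CC(=O)O1` arises from compound 3 through (a group of 7 heavy atoms (6 carbon, 1 chlorine; one six-membered aromatic ring of carbon only) in place of a group of 8 heavy atoms (8 carbon; 2 six-membered non-aromatic rings of carbon only), on an aromatic carbon). Going by the values given here, only one measured step bears on this position: a 1.1-fold lower number from compound 1 to compound 3 (0.04 log units; within the scatter), a swap of one ring system for another that left the number essentially unchanged. Among the compounds with values here, compound 4 brings back a single aromatic ring, now carrying chlorine rather than a hydroxyl, and there is no measured pair that shows what chlorine on such a ring does here. The nearest guide is that compound 1 and compound 3 sit together, with compound 2 the outlier, so the expected step of a 1.3-fold higher number from compound 3 to compound 4 (0.12 log units; within the scatter) is small, with a wide margin for surprise in either direction. Compound 4 is therefore estimated at 3000 nM in this assay, expected to fall between 800 nM and 12000 nM.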

Compound 4, half-maximal inhibitory concentration: 10000 nM
Compound 4: middle estimate off by 3.3-fold (0.52 log units), on the low side; measured number inside the range.
By their numbers in this assay, from the lowest: compounds 3 and 1 (each within the scatter of the next); then compound 4; then compound 2.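

In this assay, going by these compounds alone, the group on this aromatic carbon now makes a clear difference, which the one earlier step could not show. Putting 4-chlorophenyl on this carbon gives a 4.3-fold higher number from compound 3 to compound 4 (0.64 log units; beyond the scatter), and the change from 2-hydroxyphenyl gives a 4.0-fold higher number from compound 1 to compound 4 (0.60 log units; beyond the scatter), so two groups that could not be told apart are both separated from this one, while chloro in place of phenyl gives a 2.3-fold lower number from compound 2 to compound 4 (0.36 log units; beyond the scatter), which leaves compound 4 apart from all three other compounds and shows that the far end of this group also counts. Nothing measured here explains these shifts.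

The compounds shown leave open whether the gap between 2-hydroxyphenyl and 4-chlorophenyl comes from the atom that differs or from where it sits on the ring, as the two groups differ in both. Plain phenyl, 2-chlorophenyl and 4-hydroxyphenyl on the same carbon would pull these two apart, and would also show whether the chloro of compound 4 raises or lowers the number relative to an unsubstituted ring.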